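The source may report more compounds than this note shows. Statements on the series, on what has been measured and on what is new or still open speak of the compounds shown alone.

Compound 2 `CC(=O)NCC[C@@H]1C[C@@H](c2ccc(F)c(F)c2)[C@H](NC(=O)c2cc(-c3c(Cl)cnn3C)c(Cl)o2)CN1` and compound 1 `CNC(=O)C[C@@H]1C[C@@H](c2ccc(Cl)c(Cl)c2)[C@H](NC(=O)c2cc(-c3c(Cl)cnn3C)c(Cl)o2)CN1` share the same core and were both tested in an assay for inhibition of RAC-alpha serine/threonine-protein kinase (Homo sapiens), read by HTRF, with a stated time of 1 h; a higher number here means a weaker inhibitor, a lower number a stronger inhibitor. In this assay compound 1 gives 2.64 nM, and compound 2 gives 2.49 nM; the two numbers lie within the scatter of each other, so compound 2 stands level with compound 1 rather than apart from it. Compound 3 `CNC(=O)C[C@@H]1C[C@@H](c2ccc(F)c(F)c2)[C@H](NC(=O)c2cc(-c3c(Cl)cnn3C)c(Cl)o2)CN1` has not yet been measured. It differs from compound 2 in a single place: methylcarbamoyl in place of acetamidomethyl on a saturated chain carbon bound to a saturated ring carbon. Within the data shown here, no pair of measured compounds shows this change on its own. Compound 1, however, already carries a methylcarbamoyl group on a saturated chain carbon bound to a saturated ring carbon, and it gives 2.64 nM in this assay. The step from compound 2 to compound 3 is therefore expected to be small, a 1.1-fold higher number from compound 2 to compound 3 (0.04 log units; within the scatter), with no direction beyond the scatter. Compound 3 is estimated at 2.7 nM, within a range from 1.3 nM to 5.5 nM.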

Compound 3, half-maximal inhibitory concentration: 1.37 nM
Compound 3: middle estimate off by 2.0-fold (0.29 log units), on the high side, within the range that was stated.
By their numbers in this assay, from the lowest: compounds 3, 2 and 1 (each within the scatter of the next).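

In this assay, the swap of acetamidomethyl for methylcarbamoyl on a saturated chain carbon bound to a saturated ring carbon can now be read on its own, as a 1.8-fold lower number from compound 2 to compound 3 (0.26 log units; within the scatter). Among these compounds, the aryl group on a saturated ring carbon can also be read on its own for the first time: 3,4-difluorophenyl in place of 3,4-dichlorophenyl gives a 1.9-fold lower number from compound 1 to compound 3 (0.28 log units; within the scatter), so neither single change moves the number beyond the scatter. Nothing at hand bears on what lies behind these two steps.

On these data alone, each change is seen only once, so whether the chain step would look the same with 3,4-dichlorophenyl in place remains open. Also open is whether a carboxylic acid, an amine or a longer chain at this position would stay within the scatter of these compounds.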